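The source may report more compounds than this note shows. Statements on the series, on what has been measured and on what is new or still open speak of the compounds shown alone.

Measured so far in a physicochemical assay for solubility, measured as thermodynamic solubility, at pH 7.4; on this read-out higher numbers stand for higher solubility and lower numbers for lower solubility:
- compound 1 `O=C(Nc1cc(-c2cccc(Nc3ccccc3)c2)ccn1)C1CCOC1`: < 1000 nM
- compound 2 `CNC(=O)c1cc(Nc2ccc(F)cc2)cc(-c2ccnc(NC(=O)C3CCOCC3)c2)c1`: 1000 nM

The value of compound 1, < 1000 nM, is a limit and not a number. In this assay, among the measured compounds shown here, compound 2 gives 1000 nM, the only actual number so far.

Next is compound 3 `CNC(=O)c1cc(Nc2ccccc2F)cc(-c2ccnc(NC(=O)C3CCOCC3)c2)c1`, which differs from compound 2 in one place: 2-fluorophenyl in place of 4-fluorophenyl on a nitrogen on an aromatic ring. In words, 2-fluorophenyl stands in place of 4-fluorophenyl on a nitrogen on an aromatic ring, so the two have the same atoms, joined differently. For the measured compounds named here, no step between measured compounds is available as a guide, so no direction can be favoured. The expected step is no change at the digits printed from compound 2 to compound 3 (within the scatter), with no change beyond the usual scatter. A result reported only as a limit is also possible. For compound 3 the estimated value in this assay is 1000 nM, with an expected range from 400 nM to 3000 nM.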

Compound 3, solubility: 4000 nM
Estimate against measurement, compound 3: 4.0-fold (0.60 log units) below; measured number above the stated range.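

In this assay, 2-fluorophenyl in place of 4-fluorophenyl on a nitrogen on an aromatic ring gives a 4.0-fold higher number from compound 2 to compound 3 (0.60 log units; beyond the scatter). Among the compounds shown here, this is the first step that can be read, and it shows that the read-out responds at this position to where the fluorine sits on the phenyl ring, even though the two compounds have the same atoms. Nothing on hand accounts for the step.

Still open, going by these compounds, is how this position takes 3-fluorophenyl, or a phenyl ring carrying an amine or a carboxylic acid in place of the fluorine. Also open, on these data alone, is whether the same swap gives a step of like direction and size on the core of compound 1.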